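A Methoxybenzyl Group in Place of Cyclopropylmethyl

This account rests on a few compounds, and the source may have more. Where it says the series, first, only, none or still open, it means among the compounds named here.

Three compounds that share one core have been examined in an ADME assay for permeability, using PAMPA, with a stated time of 30 min, at pH 7.4; a higher number here means that the compound crosses the layer faster, a lower number that the compound crosses the layer more slowly. Compound 1 `COc1ccc(Cn2c(-c3ccccc3)c(-c3ccccc3)c3c(=N)n(C4CCOCC4)cnc32)cc1` is recorded as "nd" (no result reported) in this assay. Compound 2 `COc1ccc(-c2c(-c3ccc(OC)cc3)n(Cc3ccccc3)c3ncn(CCCO)c(=N)c23)cc1` reaches > 1000 10^-6 cm/s in this assay, which is a limit of the measurement rather than a number. Compound 3 `N=c1c2c(-c3ccccc3)c(-c3ccccc3)n(CC3CC3)c2ncn1CC1CCOCC1` likewise reaches > 1000 10^-6 cm/s in this assay, again a limit and not a number. Compound 3 therefore stands at the upper edge of what the method can report, because of the limit of > 1000 10^-6 cm/s in this assay, at which 2 of the 3 values shown sit, and no single figure separates it from compound 2.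

Compound 4 `COc1ccc(Cn2c(-c3ccccc3)c(-c3ccccc3)c3c(=N)n(CC4CCOCC4)cnc32)cc1` differs from compound 3 in one place: 4-methoxyphenyl in place of cyclopropyl on a saturated chain carbon bound to an aromatic nitrogen. Cut one bond further out, the change reads as cyclopropylmethyl to 4-methoxybenzyl.

Among the compounds with values here, no step between two measured compounds is available to calibrate this change. Since compound 2, which also carries a benzyl group on that nitrogen, and compound 3 both sit at the limit, the step of a number no higher from compound 3 to compound 4 (the limit leaves the size open) is expected to be none beyond the usual scatter, and compound 4 is expected to reach the limit again. The estimate for compound 4 in this assay is 1000 10^-6 cm/s, with a range from 600 10^-6 cm/s to 1500 10^-6 cm/s.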

Compound 4, apparent permeability: 1270 10^-6 cm/s
The estimate for compound 4 lay 1.3-fold (0.10 log units) below the measured number, and the stated range covers the measured number.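

The step from compound 3 to compound 4 in this assay cannot be read, because compound 3 carries only a limit and not a number: the limit of > 1000 10^-6 cm/s in this assay, at which 2 of the 4 values shown sit.

The compounds shown leave open how large the change from cyclopropylmethyl to 4-methoxybenzyl is in this assay, as no single number for compound 3 exists to set against compound 4.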